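The source may report more compounds than this note shows. Statements on the series, on what has been measured and on what is new or still open speak of the compounds shown alone.

Measured so far:
Compound 1 `CC1=C(N2CC2)C(=O)C(Cc2ccccc2)=C(N2CC2)C1=O` gives 4.69 in a functional assay on L1210 cells (Mus musculus), with a stated time of 12 days; on this read-out lower numbers stand for lower potency and higher numbers for higher potency (the scale is a negative logarithm).
Compound 2 `CC1=C(N2CC2)C(=O)C(CCCOC(N)=O)=C(N2CC2)C1=O` gives 5.93 in this assay.

Going by the values given here, compound 2 holds the higher of the two numbers; its only neighbour, compound 1, sits beyond the scatter below it. Among the compounds with values here, the single measured step, a number 1.24 log units higher from compound 1 to compound 2 (beyond the scatter), is large, and it goes with the swap of a phenyl for a 2-(carbamoyloxy)ethyl group on a saturated chain carbon bound to a double-bonded ring carbon.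

Compound 3 `COCCC1=C(N2CC2)C(=O)C(C)=C(N2CC2)C1=O` has not yet been measured. Its change from compound 2 is methoxy in place of (carbamoyloxy)methyl on a saturated chain carbon, two bonds along the chain from a double-bonded ring carbon. Read one bond further out, the side chain goes from 2-(carbamoyloxy)ethyl to methoxymethyl. Within the data shown here, the one step that bears on this is a number 1.24 log units higher from compound 1 to compound 2 (beyond the scatter), where bringing in the 2-(carbamoyloxy)ethyl chain went with a large rise; compound 3 gives that group up, while keeping a short chain in place of the phenyl ring of compound 1. A drop beyond the scatter is therefore expected, though smaller than the earlier rise, giving an expected step of a number 0.73 log units lower from compound 2 to compound 3 (beyond the scatter). The estimate for compound 3 in this assay is 5.2, within 4.6 to 5.8.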

Compound 3, logarithm of the reciprocal of the active concentration, log(1/C): 5.42
The estimate for compound 3 lay 0.22 log units below the measured number; the measured number falls inside the stated range.
By their numbers in this assay, from the lowest: compound 1; then compound 3; then compound 2.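

The rise over the phenyl group does not depend on the carbamate: in this assay, methoxymethyl in place of phenyl still goes with a number 0.73 log units higher from compound 1 to compound 3 (beyond the scatter), even though this chain carries no carbamoyloxy group. The carbamate-bearing chain nevertheless keeps an edge, since the change from 2-(carbamoyloxy)ethyl to methoxymethyl goes with a number 0.51 log units lower from compound 2 to compound 3 (beyond the scatter). Among these three compounds, then, both open chains stand above the phenyl group, and the one with the carbamoyloxy group stands highest, so this position responds to more than the presence of that one group. No measurement shown here accounts for these differences.

The change from compound 2 to compound 3 alters both the length of the chain and the group at its end, so the two contributions cannot be separated. A 2-methoxyethyl chain would test length alone, while a 2-hydroxyethyl chain, a plain propyl chain or a chain ending in an amine would show how far the number depends on the group at the end.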